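This account rests on a few compounds, and the source may have more. Where it says the series, first, only, none or still open, it means among the compounds named here.

Measured compounds:
- compound 1, `CSc1cccc(-c2nc(N)nc(N)n2)c1`, 2.16
- compound 2, `Cc1c(N(C)C)c(=O)n(-c2ccccc2)c(=O)n1CCO`, 0.85
- compound 3, `Cc1c(N(C)C)c(=O)n(CCO)c(=O)n1-c1ccccc1`, 1.12

In a physicochemical assay for lipophilicity (a lower number here means a more polar compound, a higher number a more lipophilic compound), compound 1 gives the highest of the three numbers. Compound 3 stands nearest to it, with a number that is lower by a gap beyond the scatter, and compound 2 stands furthest, lower again by a gap beyond the scatter. Compounds 2 and 3 share a core that differs from the core of compound 1, so none of these three pairs counts as a single change in one place.

The step under consideration leads from compound 1 to compound 4, `Nc1nc(N)nc(-c2cccc(SC(F)(F)F)c2)n1`. The change is trifluoromethyl in place of methyl on a sulfur. Within the data shown here, no measured pair in this set shows this exchange, so the expectation rests on the structural change alone. The step from compound 1 to compound 4 in this assay is expected to go upward, by a number 0.89 log units higher from compound 1 to compound 4 (beyond the scatter), clearly beyond the scatter. Compound 4 is thus estimated to give 3.05 in this assay, within a range from 2.6 to 3.5.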

Compound 4, partition coefficient: 3.2
The estimate for compound 4 lay 0.15 log units below the measured number; the measured number falls inside the stated range.
By their numbers in this assay, from the lowest: compounds 2 and 3 (each within the scatter of the next); then compound 1; then compound 4.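

Among these compounds, this pair gives the first measured single change in the set, so the position now has a measured response where the earlier compounds offered none. In this assay, trifluoromethyl in place of methyl on a sulfur gives a number 1.04 log units higher from compound 1 to compound 4 (beyond the scatter), a large step for an exchange at this one place. No measurement shown accounts for the size of this step, so it cannot be assigned to the fluorine atoms or to any other feature of the change.

The compounds shown leave open how the number would move with ethyl or a longer chain on this sulfur, or with an amine in place of the whole methylsulfanyl group. Among the compounds shown here, this pair is also the only one carrying the exchange, so whether a step of this size recurs on another core remains open.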